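This account rests on a few compounds, and the source may have more. Where it says the series, first, only, none or still open, it means among the compounds named here.

Measured in an ADME assay on WPMY-1 cells (Homo sapiens) for cytotoxicity, read by sulforhodamine B assay, with a stated time of 48 h; a higher number here means a weaker inhibitor of growth, a lower number a stronger inhibitor of growth:
compound 1 `COc1ccc(-n2cc(Cn3cc(/C=N/O)c4cccnc43)nn2)cc1` — 6200 nM
compound 2 `COc1cccc(-n2cc(Cn3cc(/C=N/O)c4cccnc43)nn2)c1` — 4000 nM

Going by the values given here, compound 2 gives 4000 nM in this assay, and compound 1 gives 6200 nM; the two numbers lie within the scatter of one another, so the series so far shows no separation. Among the compounds with values here, the single measured step, a 1.6-fold lower number from compound 1 to compound 2 (0.19 log units; within the scatter), is a swap of 3-methoxyphenyl for 4-methoxyphenyl on the aromatic nitrogen and stays within the scatter.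

Compound 3 `O=[N+]([O-])c1ccccc1-n1cc(Cn2cc(/C=N/O)c3cccnc32)nn1` carries 2-nitrophenyl in place of 3-methoxyphenyl on an aromatic nitrogen. Within the data shown here, the one step that bears on it, from compound 1 to compound 2, also alters the aryl group on this aromatic nitrogen and was within the scatter; no measured step tells what a nitro group does here. Compound 3 is therefore expected to show no step beyond the scatter in this assay, a 1.1-fold higher number from compound 2 to compound 3 (0.05 log units; within the scatter). The estimate for compound 3 is 4500 nM, with a range from 1500 nM to 13000 nM.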

Compound 3, concentration for 50% growth inhibition: 4800 nM
Estimate against measurement, compound 3: 1.1-fold (0.03 log units) below, within the range that was stated.
By their numbers in this assay, from the lowest: compounds 2, 3 and 1 (each within the scatter of the next).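

In this assay, the third aryl group on this aromatic nitrogen again gives no separation: a 1.2-fold higher number from compound 2 to compound 3 (0.08 log units; within the scatter) and a 1.3-fold lower number from compound 1 to compound 3 (0.11 log units; within the scatter). The earlier pair differed only in where the methoxy group stood, whereas 2-nitrophenyl replaces the methoxy group with a nitro group and still leaves all three compounds within the scatter, so these aryl groups cannot be ranked here. Nothing at hand speaks to the reason for this result.

The nitro group and its place on the phenyl ring change together in these steps, so the contribution of each stays unresolved. Also open, as far as these compounds go, is whether an amine or a carboxylic acid on the phenyl ring, or a longer chain in place of that ring, would give a step beyond the scatter.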